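This account rests on a few compounds, and the source may have more. Where it says the series, first, only, none or still open, it means among the compounds named here.

Measured compounds:
compound 1 `Cc1nc2ccc(Br)cc2c(=O)n1NCc1nnc(/N=C/c2ccc(N(C)C)cc2)s1` — 50%
compound 2 `COc1cc(/C=N/c2nnc(CNn3c(C)nc4ccc(Br)cc4c3=O)s2)ccc1O` — 50%

In a functional assay on the whole organism (strain albino) with Rattus norvegicus as the target, in the maximal electroshock model, with a stated time of 1 h, at a dose of 30 mg/kg by the intraperitoneal route (on this read-out higher numbers stand for more inhibition at the one dose given (going by the name of the read-out) and lower numbers for less inhibition), compound 1 gives 50% and compound 2 gives 50%; the step of no change at the digits printed from compound 1 to compound 2 (within the scatter) is within the scatter, so compound 2 stands level with compound 1 on these numbers. Compound 3 `Cc1nc2ccc(Br)cc2c(=O)n1NCc1nnc(/N=C/c2ccc(O)cc2)s1` is the next member; the change from compound 2 is hydrogen in place of methoxy on an aromatic carbon. Among the measured compounds shown here, the one measured step, no change at the digits printed from compound 1 to compound 2 (within the scatter), concerns the same aromatic ring and was flat, so no step beyond the scatter is expected in this assay here either. Compound 3 is estimated at 50%, range 30% to 70%, meaning an expected step of no change at the digits printed from compound 2 to compound 3 (within the scatter).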

Compound 3, a percentage reported as inhibition, in the whole organism at one dose (the size of the read-out at that dose, not a potency): 50%
Estimate against measurement, compound 3: no gap at the digits printed; the range from low to high includes it.
By their numbers in this assay, from the lowest: compounds 1, 2 and 3 (each within the scatter of the next).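

In this assay, hydrogen in place of methoxy on the aromatic carbon ortho to the hydroxy group gives no change at the digits printed from compound 2 to compound 3 (within the scatter) and so the simpler 4-hydroxyphenyl holds the read-out as well as 4-hydroxy-3-methoxyphenyl. Hydroxy in place of dimethylamino on an aromatic carbon gives no change at the digits printed from compound 1 to compound 3 (within the scatter) and so this second exchange on the ring is flat as well. No available evidence bears on these flat steps. Open, from the compounds shown here alone, is whether a carboxylic acid or a primary amine on this ring would shift the read-out. A single-dose percentage also leaves relative potency open.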